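This account rests on a few compounds, and the source may have more. Where it says the series, first, only, none or still open, it means among the compounds named here.

In a functional assay on MDA-MB-231 cells (Homo sapiens) for inhibition, read by sulforhodamine B assay, with a stated time of 48 h (on this read-out lower numbers stand for higher toxicity in this test and higher numbers for lower toxicity in this test), compound 1 `COc1cc(-c2nn(-c3cccc(NC(=O)Nc4cc(C(F)(F)F)cc(C(F)(F)F)c4)c3)cc2-c2ccncc2)ccc1Cl` gives 3000 nM. Compound 2 `COc1cc(-c2nn(-c3cccc(NC(=O)c4cccc(C(F)(F)F)c4)c3)cc2-c2ccncc2)ccc1Cl` reaches only a limit of the assay, > 50000 nM, so it has no exact number on this scale. Compound 3 `COc1cc(-c2nn(-c3cccc(NC(=O)Nc4ccc(Cl)c(C(F)(F)F)c4)c3)cc2-c2ccncc2)ccc1Cl` differs from compound 2 at one place, with (4-chloro-3-(trifluoromethyl)phenyl)amino in place of 3-(trifluoromethyl)phenyl on a carbonyl carbon. Among the measured compounds shown here, no measured step connects these compounds directly. The carbonyl carbon of compound 1 also carries an aromatic amino group, and in this assay compound 1 gives 3000 nM, so a clear move toward lower numbers, beyond the usual scatter, is expected for compound 3. The expected size of this move is an at least 10-fold lower number from compound 2 to compound 3 (1.00 log units; beyond the scatter). The estimate in this assay for compound 3 is 5000 nM, with an expected range from 1500 nM to 30000 nM.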

Compound 3, concentration lethal to 50% of the cells: 13300 nM
The estimate for compound 3 lay 2.7-fold (0.42 log units) below the measured number; low and high end bracket the measured number.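

In this assay, replacing 3-(trifluoromethyl)phenyl with (4-chloro-3-(trifluoromethyl)phenyl)amino on a carbonyl carbon gives an at least 3.7-fold lower number from compound 2 to compound 3 (0.57 log units; beyond the scatter). Among the compounds shown here, this is the first reading of a single change at this place, and it shows that the change moves the number in this test beyond the usual scatter. Compound 2 holds only a limit of the assay, so the step gives a floor and not a full size: the limit of > 50000 nM in this assay, at which 1 of the 3 values shown sits.

The entering group brings both an amino nitrogen and a chlorine, so the compounds shown do not separate the two. On these data alone, a (3-(trifluoromethyl)phenyl)amino group without the chlorine, or a 4-chloro-3-(trifluoromethyl)phenyl group joined directly to the carbonyl carbon, would tell them apart, and how a methylamino group on that carbon would read remains open.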